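The compounds below may be only part of what the source reports. "The series", "measured", "known", "first", "only" and "open" are said of these compounds alone.

Measured so far in an assay on microsomes for inhibition of acyl-CoA:cholesterol acyltransferase (Oryctolagus cuniculus); a higher number here means a weaker inhibitor, a lower number a stronger inhibitor: compound 1, `CC(C)c1cccc(C(C)C)c1NC(=O)NCC1(c2ccc(F)cc2)CCCC1`, gives 23 nM. Compound 2, `CC(C)c1cccc(C(C)C)c1NC(=O)NCC1(c2ccccc2C(F)(F)F)CCCC1`, gives 18 nM. Compound 3, `COC(=O)c1ccc(C2(CNC(=O)Nc3c(C(C)C)cccc3C(C)C)CCCC2)cc1`, gives 360 nM.

Compound 1 stands second highest of the three numbers; compound 2 lies within the scatter of it (a 1.3-fold lower number from compound 1 to compound 2 (0.11 log units; within the scatter)), compound 3 far from it (a 16-fold higher number from compound 1 to compound 3 (1.19 log units; beyond the scatter)).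

Compound 4, `CC(C)c1cccc(C(C)C)c1NC(=O)NCC1(c2cccc(CO)c2)CCCC1`, differs from compound 1 by 3-(hydroxymethyl)phenyl in place of 4-fluorophenyl on a saturated ring carbon. The step that bears on it most is a 16-fold higher number from compound 1 to compound 3 (1.19 log units; beyond the scatter), which likewise put a larger substituent in place of the fluorine on the aromatic ring and was large; a 20-fold higher number from compound 2 to compound 3 (1.30 log units; beyond the scatter) points the same way, while a 1.3-fold lower number from compound 1 to compound 2 (0.11 log units; within the scatter) shows an aromatic swap can also pass within the scatter. A weakening step is therefore expected, smaller than that to compound 3 given the different group and place. Compound 4 is estimated at 100 nM, range 30 nM to 400 nM, a step of a 4.3-fold higher number from compound 1 to compound 4 (0.64 log units; beyond the scatter) expected from compound 1.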

Compound 4, half-maximal inhibitory concentration: 15 nM
The estimate for compound 4 lay 6.7-fold (0.82 log units) above the measured number; measured number outside the range, below it.
By their numbers in this assay, from the lowest: compounds 4, 2 and 1 (each within the scatter of the next); then compound 3.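

In this assay, 3-(hydroxymethyl)phenyl on the saturated ring carbon stays level with the earlier aryl groups, with a 1.5-fold lower number from compound 1 to compound 4 (0.19 log units; within the scatter) and a 1.2-fold lower number from compound 2 to compound 4 (0.08 log units; within the scatter). The large loss with 4-(methoxycarbonyl)phenyl therefore does not extend to every oxygen-bearing aryl group at this position, as a 24-fold lower number from compound 3 to compound 4 (1.38 log units; beyond the scatter) shows. Nothing available explains this difference. Still open, on these data alone, is whether an amine or a carboxylic acid in place of the hydroxyl, or a longer chain carrying it, keeps the number in this range. Compound 3 and compound 4 also differ in both the group and its ring position, so the contribution of each remains unseparated.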